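The compounds below may be only part of what the source reports. "The series", "measured", "known", "first", "only" and "open" are said of these compounds alone.

Measured so far, in a functional assay on the whole organism (stomach) for inhibition, with Rattus norvegicus as the target, at a dose of 100 mg/kg by the intraduodenal route; on this read-out higher numbers stand for more inhibition at the one dose given (going by the name of the read-out) and lower numbers for less inhibition:

compound 1 `Cc1ccc(=O)n(CCCCCCC(=N)S)n1` gives 29.5%
compound 2 `N=C(S)CCCCCCn1nc(-c2ccccc2)ccc1=O` gives 33.9%

Within the data shown here, compound 2 has the higher of the two numbers, but the only measured step, a number 4.4 percentage points higher from compound 1 to compound 2 (within the scatter), lies within the scatter, so the two compounds cannot be told apart on this read-out. That step swaps a group on the aromatic part of the shared core and leaves the chain untouched.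

The next compound, compound 3 `CN(C)C(=S)CCn1nc(-c2ccccc2)ccc1=O`, changes something else: a group of 5 heavy atoms (3 carbon, 1 nitrogen, 1 sulfur; no ring) in place of a group of 7 heavy atoms (5 carbon, 1 nitrogen, 1 sulfur; no ring), on a saturated chain carbon, two bonds along the chain from an aromatic nitrogen. The chain becomes shorter and the group at its end changes as well, while the aromatic part of compound 2 is kept. Among the measured compounds shown here, no measured pair shows what happens when the chain or its end group is altered, so the one step in hand, which lies within the scatter in any case, gives no guidance for this change.

With nothing to lean on, the step from compound 2 to compound 3 is expected to be a number 3.9 percentage points lower from compound 2 to compound 3 (within the scatter), that is, none beyond the scatter, with wide uncertainty. Compound 3 is therefore estimated at 30% in this assay, with a range from 8% to 55%.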

Compound 3, a percentage reported as inhibition, in the whole organism at one dose (the size of the read-out at that dose, not a potency): 46%
Estimate against measurement, compound 3: 16 percentage points below, within the range that was stated.
By their numbers in this assay, from the lowest: compounds 1 and 2 (each within the scatter of the next); then compound 3.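

In this assay, among these compounds, this change at the chain gives the only step so far that lies beyond the scatter: a number 12.1 percentage points higher from compound 2 to compound 3 (beyond the scatter). So the place on a saturated chain carbon, two bonds along the chain from an aromatic nitrogen, can move this read-out, which the swap of phenyl in place of methyl on an aromatic carbon did not show. The group that enters has 5 heavy atoms and 0 hydrogen-bond donors, against 7 heavy atoms and 2 hydrogen-bond donors in the group that leaves, but nothing measured here bears on why the number rises.

The one step alters the length of the chain and its end group together, so the compounds shown cannot say how much of the rise belongs to either alteration. Still open, from the compounds shown here alone, is how the read-out would respond to the end group of compound 3 on a longer chain, or to an amine or a carboxylic acid at the end of the short chain of compound 3.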